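The source may hold more compounds than are shown below. What is called first, only, known or untested is meant among the compounds shown, and "the series" means these compounds.

Three compounds share one core and were tested in an assay on cells for antagonist activity at transient receptor potential cation channel subfamily V member 1 (Homo sapiens), read by FLIPR and calcium flux, with a stated time of 6 min; on this read-out lower numbers stand for stronger inhibition and higher numbers for weaker inhibition. Compound 1 `CC(C(=O)NCc1ccc(C(C)(C)C)nc1N1CCCC1)c1ccc(NS(C)(=O)=O)c(F)c1` gives 1.2 nM, and compound 2 `CC(C(=O)NCc1ccc(C(C)(C)C)nc1N1CCCCCC1)c1ccc(NS(C)(=O)=O)c(F)c1` gives 0.9 nM; the step of a 1.3-fold lower number from compound 1 to compound 2 (0.12 log units; within the scatter) lies within the scatter. Compound 3 `CCOCCOc1nc(C(C)(C)C)ccc1CNC(=O)C(C)c1ccc(NS(C)(=O)=O)c(F)c1` gives 23.9 nM, the highest of the three numbers: the steps of a 20-fold higher number from compound 1 to compound 3 (1.30 log units; beyond the scatter) and a 27-fold higher number from compound 2 to compound 3 (1.42 log units; beyond the scatter) are both large and beyond the scatter, so compound 3 sits well apart from the other two.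

Compound 4 `CC(C(=O)NCc1ccc(C(C)(C)C)nc1SC1CCCC1)c1ccc(NS(C)(=O)=O)c(F)c1` has not yet been measured. It differs from compound 3 at a single place: cyclopentylsulfanyl in place of 2-ethoxyethoxy on an aromatic carbon. The two steps that bear on this change are those that remove or install the 2-ethoxyethoxy group, a 20-fold higher number from compound 1 to compound 3 (1.30 log units; beyond the scatter) and a 27-fold higher number from compound 2 to compound 3 (1.42 log units; beyond the scatter), and both were large. Since the entering cyclopentylsulfanyl group, like pyrrolidin-1-yl and azepan-1-yl, brings a ring in place of the chain, a substantial step back toward lower numbers is expected, though not necessarily the full return seen in compound 1. The expected step is an 8.0-fold lower number from compound 3 to compound 4 (0.90 log units; beyond the scatter). Compound 4 is therefore estimated at 3 nM, with a range from 0.8 nM to 12 nM.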

Compound 4, inhibition constant: 2.5 nM
For compound 4 the middle estimate is 1.2-fold (0.08 log units) above the measured one, and the stated range covers the measured number.
By their numbers in this assay, from the lowest: compounds 2 and 1 (each within the scatter of the next); then compound 4; then compound 3.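

In this assay, the position next to the ring nitrogen proved not to depend on a ring joined through nitrogen: with cyclopentylsulfanyl in place of 2-ethoxyethoxy, there is a 9.6-fold lower number from compound 3 to compound 4 (0.98 log units; beyond the scatter), so a carbon ring joined through sulfur also lies far closer to the pyrrolidin-1-yl and azepan-1-yl compounds than to the 2-ethoxyethoxy compound. The return is still incomplete, with a 2.1-fold higher number from compound 1 to compound 4 (0.32 log units; beyond the scatter) and a 2.8-fold higher number from compound 2 to compound 4 (0.44 log units; beyond the scatter), both modest but beyond the scatter. No measurement available here accounts for these differences.

The compounds shown leave open whether the ring or the sulfur link matters more for the difference from 2-ethoxyethoxy. A cyclopentyloxy group, a cyclopentylamino group or an open-chain pentylsulfanyl group at this position would separate the two.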